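Cytotoxicity notes: hydroxyphenyl in place of dimethoxyphenyl

The source may hold more compounds than are shown below. What is called first, only, known or untested is meant among the compounds shown, and "the series" means these compounds.

Measured so far:
- compound 1 `CC(C)N(Cc1cccc(OCCCCCC(=O)O)c1)C(=O)c1ccc(-c2cccc(O)c2)cc1`: > 26000 nM
- compound 2 `CCOC(=O)CCCCCOc1cccc(CN(C(=O)c2ccc(-c3cc(OC)cc(OC)c3)cc2)C(C)C)c1`: > 26000 nM

Both numbers come from an ADME assay on BJ cells (Homo sapiens) for cytotoxicity, read by CellTiter-Glo and resazurin assay, with a stated time of 72 h; a lower number here means that less compound is needed, a higher number that more compound is needed for the effect. For compound 1 the value > 26000 nM is a limit of the assay, not a number. For compound 2 the value > 26000 nM is likewise a limit, and compound 2 stands at the limit of > 26000 nM in this assay, at which 2 of the 2 values shown sit. Within the data shown here, compound 2 thus has only a limit in this assay, and the one further value shown is a limit too. Among the measured compounds shown here, no two measured compounds differ in a single place, so no measured step can be read from them.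

Compound 3 `CCOC(=O)CCCCCOc1cccc(CN(C(=O)c2ccc(-c3cccc(O)c3)cc2)C(C)C)c1` follows from compound 2 by 3-hydroxyphenyl in place of 3,5-dimethoxyphenyl on an aromatic carbon. Compound 1, which also carries 3-hydroxyphenyl, gives only the limit > 26000 nM. The step that the limit leaves unreadable from compound 2 to compound 3 is therefore expected to be none beyond the scatter. Compound 3 is estimated at 30000 nM in this assay, within 15000 nM to 60000 nM, and most probably the assay will again report only a limit for compound 3.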

Compound 3, half-maximal effective concentration: > 26000 nM
Compound 3 ended at the assay's limit; the forecaster's own chance of this, stated with the estimate: 85%; the middle value lies beyond the limit too.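

No new step can be read in this assay from compound 2 to compound 3 or from compound 1 to compound 3, because all three values are limits of the assay, not numbers: the limit of > 26000 nM in this assay, at which 3 of the 3 values shown sit.

The compounds shown leave open where each true value lies beyond that limit, and whether either change alters cytotoxicity at all.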